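Swapping dimethylamino for a methylpyrazole on a weak antagonist

The compounds below may be only part of what the source reports. "The series", "measured", "known", "first", "only" and "open" are said of these compounds alone.

Within the data shown here, compound 1 `Cc1cc(NNC(=O)Nc2cc(Cl)nc(Cl)c2)ncc1N(C)C` is the only compound of the pair that returns a number in a functional assay on CHO cells for antagonist activity at sphingosine 1-phosphate receptor 2 (Homo sapiens), read by fluorescence and calcium flux, with a stated time of 3 min (a higher number here means a weaker inhibitor, a lower number a stronger inhibitor), where compound 1 gives 3600 nM. Compound 2 `Cc1cc(CO)nc(NNC(=O)Nc2cc(Cl)nc(Cl)c2)c1` gives only a limit of this assay, > 6600 nM, and that is the limit of > 6600 nM in this assay, at which 1 of the 2 values shown sits. Compound 3 `Cc1cc(NNC(=O)Nc2cc(Cl)nc(Cl)c2)ncc1-c1cnn(C)c1` has not yet been measured. It differs from compound 1 by 1-methyl-1H-pyrazol-4-yl in place of dimethylamino on an aromatic carbon of the six-membered aromatic ring with one nitrogen, ortho to a methyl group, two atoms from the ring nitrogen and para to a large group. Among the measured compounds shown here, no measured pair shares this change, so nothing here sets the size of the step. The step from compound 1 to compound 3 is expected to be small, a 1.3-fold lower number from compound 1 to compound 3 (0.11 log units; within the scatter), not clearly beyond the scatter in either direction. Compound 3 is therefore estimated at about 2800 nM, with a range from 700 nM to 9000 nM.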

Compound 3, half-maximal inhibitory concentration: 2600 nM
Estimate against measurement, compound 3: 1.1-fold (0.03 log units) above; the range from low to high includes it.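

In this assay, the change reads as a 1.4-fold lower number from compound 1 to compound 3 (0.14 log units; within the scatter), so at this aromatic carbon, ortho to a methyl group and para to a large group, 1-methyl-1H-pyrazol-4-yl and dimethylamino cannot be told apart. This is the first step shown at this position, and it shows that an open amine can give way to a five-membered aromatic ring with no shift beyond the scatter, in either direction. Nothing measured here explains why the two groups read alike.

From the compounds shown here alone, it remains open whether other groups on this carbon, such as a methoxy group, a carboxylic acid or a phenyl ring, would move the number beyond the scatter. Also open, going by these compounds, is whether the neighbouring methyl group could be replaced by an ethyl group or a chlorine atom without a change in the read-out.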